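Alkyl on the aromatic nitrogen: propyl in place of isopropyl

The source may hold more compounds than are shown below. What is called first, only, known or untested is meant among the compounds shown, and "the series" means these compounds.

Three measured compounds share one core. In a functional assay with Alpha-1D adrenergic receptor (Homo sapiens) as the target, read by calcium flux (on this read-out lower numbers stand for smaller maximal responses and higher numbers for larger maximal responses), compound 1 `Cc1nc(-c2ccccc2NCC2=NCCN2)n(C)n1` gives 0%. Compound 2 `CC(C)n1ncnc1-c1ccccc1NCC1=NCCN1` gives 37% in this assay, the second highest of the three numbers, separated from both others by more than the scatter. Compound 3 `c1ccc(-c2nc[nH]n2)c(NCC2=NCCN2)c1` gives 123% in this assay. Compound 4 `CCCn1ncnc1-c1ccccc1NCC1=NCCN1` has not been measured; against compound 2 it shows (propyl in place of isopropyl on an aromatic nitrogen). For the measured compounds named here, no step between measured compounds covers this change. A step in this assay not beyond the scatter, in either direction, is expected, because compound 2 gives 37% with isopropyl already there. For compound 4 the estimate is 40%, with a range from 10% to 80%. This estimate means an expected step of a number 3 percentage points higher from compound 2 to compound 4 (within the scatter).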

Compound 4, largest response reached (reported as maximal response), in percent of the reference or control that the assay uses: 57%
Estimate against measurement, compound 4: 17 percentage points below, within the range that was stated.
By their numbers in this assay, from the lowest: compound 1; then compound 2; then compound 4; then compound 3.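

On the aromatic nitrogen, the response in this assay shifts with the arrangement of three carbons alone, with a step that reads a number 20 percentage points higher from compound 2 to compound 4 (beyond the scatter) and favours the straight chain of this pair. The change alters no count of heavy atoms, donors or acceptors and no net charge, so this position distinguishes propyl from isopropyl even with the same atoms. Nothing at hand accounts for the step.

As far as these compounds go, what a butyl chain or a methoxyethyl group would give on this nitrogen stays open. So does whether this step would hold with the methyl group of compound 1 on the shared core.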